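An Ethenyl Link Added to Compound 2

The source may report more compounds than this note shows. Statements on the series, on what has been measured and on what is new or still open speak of the compounds shown alone.

Of the compounds shown here, two sharing one core have been measured so far, and they differ in the long arm attached to that core. In a functional assay on HCT-116 cells (Homo sapiens) for antiproliferative activity, read by sulforhodamine B assay, with a stated time of 72 h (on this read-out lower numbers stand for stronger inhibition and higher numbers for weaker inhibition), compound 1 `CC(=O)CCCCCOc1ccc2c(OCCn3nc(-c4cnn(C)c4)ccc3=O)ccnc2c1` gives > 10000 nM as a limit of the assay, not as a number. Within the data shown here, compound 2 `Cn1cc(-c2ccc(=O)n(CCOc3ccnc4cc(OCc5ccc(C(=O)Nc6ccccc6N)cc5)ccc34)n2)cn1` gives 1800 nM in this assay and so holds the only true number available.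

Compound 3 `Cn1cc(-c2ccc(=O)n(CCOc3ccnc4cc(OCc5ccc(/C=C/C(=O)Nc6ccccc6N)cc5)ccc34)n2)cn1` has yet to be measured. It keeps the core of compound 2 and changes one place: 2-((2-aminophenyl)carbamoyl)ethenyl stands in place of (2-aminophenyl)carbamoyl on an aromatic carbon, para to a large group (2-((2-aminophenyl)carbamoyl)ethenyl in place of (2-aminophenyl)carbamoyl on an aromatic carbon).

Among the measured compounds shown here, no measured pair shows this kind of change, so any expectation starts from compound 2 at 1800 nM and has to stay wide. A modest move toward stronger inhibition in this assay is expected, no larger than the usual scatter, and the estimated size is a 1.8-fold lower number from compound 2 to compound 3 (0.26 log units; within the scatter) in all. For compound 3 the estimated value is 1000 nM (expected range 300 nM to 4000 nM).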

Compound 3, half-maximal inhibitory concentration: > 10000 nM
Compound 3 gave a limit, no number; the forecaster's own chance of this, stated with the estimate: 4%; middle value at least 10-fold (1.00 log units) from the limit.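

In this assay, 2-((2-aminophenyl)carbamoyl)ethenyl in place of (2-aminophenyl)carbamoyl on this aromatic carbon gives an at least 5.5-fold higher number from compound 2 to compound 3 (0.74 log units; beyond the scatter), the first step read at this position, and it shows that this position does not tolerate every change: adding the ethenyl link alone, with the same end group kept, is enough to take away the measurable inhibition seen with compound 2. In this assay compound 3 gives > 10000 nM, which is a limit of the assay and not a number. The step therefore marks only the smallest loss that fits the data, its full size stays unknown, and compound 2 remains the only compound here with a true number: the limit of > 10000 nM in this assay, at which 2 of the 3 values shown sit.

The compounds shown do not separate the double bond from the longer reach, and a saturated ethylene link carrying the same (2-aminophenyl)carbamoyl end would be the group that could tell these two apart. They also leave open how this position would read in this assay with a different end group, such as a hydroxamic acid or a carboxylic acid, in place of the (2-aminophenyl)carbamoyl group.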